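Swapping the Ring on the Sulfonyl Sulfur

The source may hold more compounds than are shown below. What is called first, only, known or untested is meant among the compounds shown, and "the series" means these compounds.

Measured compounds:
compound 1 `CNCc1cc(-c2cccnc2F)n(S(=O)(=O)c2ccccc2)c1` gives 99%
compound 2 `CNCc1cc(-c2cccnc2F)n(S(=O)(=O)c2ccsc2)c1` gives 98%
compound 3 `CNCc1cc(-c2cccnc2F)n(S(=O)(=O)c2ccoc2)c1` gives 82%

These three compounds share one core and differ only in the aromatic ring attached to the sulfonyl sulfur. In a functional assay on the whole organism (strain Jcl:SD) for inhibition, with Rattus norvegicus as the target, with stated times of 3 min and 3 h, at a dose of 1 mg/kg by the intravenous route (a lower number here means less inhibition, a higher number more inhibition at the dose given (going by the name of the read-out)), compound 3, which carries a furan-3-yl there, stands lowest of the three; its nearest neighbour is compound 2, and compound 1 is furthest away.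

The new compound 4 `CNCc1cc(-c2cccnc2F)n(S(=O)(=O)c2ccccn2)c1` is reached from compound 3 by the change (pyridin-2-yl in place of furan-3-yl on a sulfonyl sulfur).

Going by the values given here, no measured step introduces a pyridin-2-yl, so the closest guides are the steps that put a furan-3-yl in place of another ring: a number 17 percentage points lower from compound 1 to compound 3 (beyond the scatter) and a number 16 percentage points lower from compound 2 to compound 3 (beyond the scatter). Both are modest drops beyond the scatter, while a number 1 percentage points lower from compound 1 to compound 2 (within the scatter) is within the scatter. Reading these backwards, leaving the furan-3-yl for a six-membered aromatic ring is expected to recover most of that loss, so a modest rise is expected in this assay: a number 12 percentage points higher from compound 3 to compound 4 (beyond the scatter).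

Compound 4 is therefore estimated at 94%, with a plausible range from 80% to 100%.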

Compound 4, a percentage reported as inhibition, in the whole organism at one dose (the size of the read-out at that dose, not a potency): 81%
Compound 4: middle estimate off by 13 percentage points, on the high side; measured number inside the range.
By their numbers in this assay, from the lowest: compounds 4 and 3 (each within the scatter of the next); then compounds 2 and 1 (each within the scatter of the next).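

In this assay, a six-membered ring on the sulfonyl sulfur does not by itself bring back the higher level, as pyridin-2-yl gives no readable gain over furan-3-yl (a number 1 percentage points lower from compound 3 to compound 4 (within the scatter)) and falls short of the other six-membered ring, phenyl (a number 18 percentage points lower from compound 1 to compound 4 (beyond the scatter)). It also falls short of the five-membered thiophen-3-yl (a number 17 percentage points lower from compound 2 to compound 4 (beyond the scatter)), so ring size does not sort these four compounds: each size appears in both the higher pair, compounds 1 and 2, and the lower pair, compounds 3 and 4. Instead, the split follows the ring's make-up, with the oxygen-containing and nitrogen-containing rings in the lower pair and the sulfur-containing and all-carbon rings in the higher pair, though nothing available explains this split.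

The compounds shown leave open whether the nitrogen itself matters or only where it sits in the ring, a question that pyridin-3-yl or pyridin-4-yl on the sulfonyl sulfur would address. They also leave open whether an aromatic ring is needed here at all, as a saturated ring such as cyclohexyl or a small chain such as methyl would show.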